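Aryl ureas on a shared core: three measured, one expected

The source may hold more compounds than are shown below. What is called first, only, known or untested is meant among the compounds shown, and "the series" means these compounds.

Measured so far in a functional assay on the whole organism (strain albino) with Mus musculus as the target, at a dose of 100 mg/kg by the intraperitoneal route; a higher number here means more inhibition at the dose given (going by the name of the read-out), a lower number less inhibition:
compound 1 `O=C(Nc1ccccc1)Nn1c(-c2ccccc2)nc2ccccc2c1=O` gives 56%
compound 2 `Cc1ccc(NC(=O)Nn2c(-c3ccccc3)nc3ccccc3c2=O)cc1` gives 54%
compound 3 `O=C(Nc1ccc(Cl)cc1)Nn1c(-c2ccccc2)nc2ccccc2c1=O` gives 55%

Compound 3 sits second highest of the three numbers, yet its nearest neighbour is compound 1 and the gap between them lies within the scatter, as does the gap to compound 2. The three measured compounds share one core and differ only in the group carried on the amide-type nitrogen.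

Compound 4 `Cc1cccc(NC(=O)Nn2c(-c3ccccc3)nc3ccccc3c2=O)c1` carries 3-methylphenyl in place of 4-chlorophenyl on an amide-type nitrogen. Going by the values given here, three measured steps bear on this kind of change, each swapping one small group on the aromatic ring: a number 2 percentage points lower from compound 1 to compound 2 (within the scatter), a number 1 percentage points lower from compound 1 to compound 3 (within the scatter) and a number 1 percentage points higher from compound 2 to compound 3 (within the scatter). All three lie within the scatter, so the ring substituent has so far made no difference that can be told from noise. Among the compounds with values here, compound 4 moves the methyl of compound 2 to another place on the ring; no measured step covers that move, but nothing in the data suggests a shift beyond the scatter. Compound 4 is therefore expected to give about 55%, between 44% and 66%. The expected step of no change at the digits printed from compound 3 to compound 4 (within the scatter) is estimated to stay within the scatter.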

Compound 4, a percentage reported as inhibition, in the whole organism at one dose (the size of the read-out at that dose, not a potency): 59%
Estimate against measurement, compound 4: 4 percentage points below; low and high end bracket the measured number.
By their numbers in this assay, from the lowest: compounds 2, 3, 1 and 4 (each within the scatter of the next).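

In this assay, going by these compounds alone, exchanging 4-methylphenyl for 3-methylphenyl on the amide-type nitrogen gives a number 5 percentage points higher from compound 2 to compound 4 (within the scatter), the first measured step that changes where the methyl sits on the ring rather than which group is present. Against the plain phenyl group the 3-methylphenyl group gives a number 3 percentage points higher from compound 1 to compound 4 (within the scatter), and against 4-chlorophenyl it gives a number 4 percentage points higher from compound 3 to compound 4 (within the scatter), so the four aryl ureas remain within the scatter of one another at this position. No measurement shown here offers any explanation for these small differences.

Still open, from the compounds shown here alone, is whether an amine, a carboxylic acid or a longer alkyl chain on this ring would move the number beyond the scatter. Also open is how these compounds compare at doses other than the single one shown.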